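The source may report more compounds than this note shows. Statements on the series, on what has been measured and on what is new or still open speak of the compounds shown alone.

Working notes on the series in a functional assay on HeLa cells (Homo sapiens) for cytotoxicity, read by MTT assay; on this read-out lower numbers stand for stronger inhibition and higher numbers for weaker inhibition. Of the compounds shown here, three carry numbers so far. Compound 1 `CCCC(O)CC(=O)O[C@H](CC=C(C)C)C1=CC(=O)c2c(O)ccc(O)c2C1=O` gives 59300 nM, compound 2 `CCCCC(O)CC(=O)O[C@H](CC=C(C)C)C1=CC(=O)c2c(O)ccc(O)c2C1=O` gives 72200 nM and compound 3 `CCCC(CC(=O)O[C@H](CC=C(C)C)C1=CC(=O)c2c(O)ccc(O)c2C1=O)OC(C)=O` gives 51200 nM. The three sit close together: a 1.2-fold higher number from compound 1 to compound 2 (0.09 log units; within the scatter), a 1.2-fold lower number from compound 1 to compound 3 (0.06 log units; within the scatter) and a 1.4-fold lower number from compound 2 to compound 3 (0.15 log units; within the scatter) all fall inside the usual scatter. Compound 3 holds the lowest of the three numbers, with compound 1 nearest and compound 2 furthest, but neither gap exceeds the scatter, so no order among the three can be read from these data.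

Compound 4 `CCCC(C)(O)CC(=O)O[C@H](CC=C(C)C)C1=CC(=O)c2c(O)ccc(O)c2C1=O` has not yet been measured. It differs from compound 3 as follows: 1-hydroxy-1-methylbutyl in place of 1-acetoxybutyl on a saturated chain carbon bound to a carbonyl carbon. For the measured compounds named here, two measured steps bear on this. The step from compound 1 to compound 3, acetyl in place of hydrogen on an oxygen on a saturated carbon, runs opposite to part of this change and stayed within the scatter. The step from compound 1 to compound 2, a methyl added on the chain, likewise stayed within the scatter. Neither gives grounds for a step beyond the scatter in this assay.

Compound 4 is therefore expected to give about 60000 nM, within 30000 nM to 120000 nM, meaning an expected step of a 1.2-fold higher number from compound 3 to compound 4 (0.07 log units; within the scatter) from compound 3.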

Compound 4, half-maximal inhibitory concentration: 72000 nM
The estimate for compound 4 lay 1.2-fold (0.08 log units) below the measured number, and the stated range covers the measured number.
By their numbers in this assay, from the lowest: compounds 3, 1, 4 and 2 (each within the scatter of the next).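

In this assay, the position now carries a methyl in place of hydrogen on a saturated chain carbon bound to an oxygen on a saturated carbon and two saturated chain carbons, and that change gives a 1.2-fold higher number from compound 1 to compound 4 (0.08 log units; within the scatter) and so stays within the scatter, as the methyl added further along the chain did. Moving from 1-hydroxypentyl to 1-hydroxy-1-methylbutyl gives a 1.0-fold lower number from compound 2 to compound 4 (0.00 log units; within the scatter) and leaving 1-acetoxybutyl for 1-hydroxy-1-methylbutyl gives a 1.4-fold higher number from compound 3 to compound 4 (0.15 log units; within the scatter), so neither the branching of this chain nor the exchange of a hydrogen-bond acceptor for a donor separates these compounds in this read-out. No supporting measurement is available to explain why these steps remain so small.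

All four compounds share the same core and a short chain with an oxygen on it, so they do not show whether any change at this place can move the number beyond the scatter. From the compounds shown here alone, an amine or a carboxylic acid in place of the hydroxyl, or a longer chain such as a 1-hydroxyoctyl group, remains open, as does the contribution of the shared core to the numbers in this assay overall.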